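One More Methoxy Group on a Shared Core

This account rests on a few compounds, and the source may have more. Where it says the series, first, only, none or still open, it means among the compounds named here.

Compound 1 `COc1ccc(-c2cc(/C=C/C(=O)c3ccc(N)cc3)[nH]n2)cc1` and compound 3 `COc1ccc(-c2cc(/C=C/C(=O)c3ccc(N)cc3)[nH]n2)cc1OC` share a core and differ in a single change, (methoxy in place of hydrogen on an aromatic carbon). In a functional assay on SW-620 cells (Homo sapiens) for cytotoxicity, read by sulforhodamine B assay, with a stated time of 48 h, tested at 10 uM (on this read-out higher numbers stand for a weaker effect at the one concentration tested and lower numbers for a stronger effect), compound 1 gives -26%, and compound 3 gives -18%. The step of a number 8 percentage points higher from compound 1 to compound 3 (within the scatter) lies within the scatter, so these two values show no ordering between them.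

Compound 2 `COc1ccc(C(=O)/C=C/c2cc(-c3cc(OC)c(OC)c(OC)c3)n[nH]2)cc1OC` rests on a different core; the difference between the two cores is not broken down here. In this assay compound 2 gives -77%, the lowest of the three numbers, and its nearest neighbour, compound 1, stands beyond the scatter above it.

Compound 4 `COc1cc(C(=O)/C=C/c2cc(-c3cc(OC)c(OC)c(OC)c3)n[nH]2)cc(OC)c1OC` arises from compound 2 by methoxy in place of hydrogen on an aromatic carbon. This is the same kind of change as from compound 1 to compound 3, though the place is not identical: in compound 4 the carbon is also meta to a methoxy group. Since the earlier step of a number 8 percentage points higher from compound 1 to compound 3 (within the scatter) stayed within the scatter, the step of a number 3 percentage points higher from compound 2 to compound 4 (within the scatter) is expected to be small as well. Compound 4 is therefore estimated at -74%, with a range from -95% to -50%.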

Compound 4, a percentage reported as activity, at one concentration (the size of the read-out at that concentration, not a potency): -89%
Beside the measured number, compound 4's estimate is 15 percentage points above it, and the stated range covers the measured number.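

In this assay, methoxy in place of hydrogen on an aromatic carbon gives a number 12 percentage points lower from compound 2 to compound 4 (beyond the scatter), and this step does not match the one seen on the core of compound 1: the same change on two cores in this assay, a number 8 percentage points higher (within the scatter) from compound 1 to compound 3 and a number 12 percentage points lower (beyond the scatter) from compound 2 to compound 4, 20 percentage points apart, beyond the scatter of two such steps The same change therefore did not carry over unchanged between these two cores, and a step read on one of them gave no safe guide to its size or direction on the other. Going by these compounds alone, this rests on only one pair for each core, the place of the change is not identical in the two pairs, and the result does not show which feature of the cores or of that place sets the two steps apart.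

The compounds shown leave open whether a hydroxy group or an ethoxy group in place of that hydrogen would behave alike on both cores. They also leave open how the methoxy change would fare on a third core.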